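Removing a methyl from compound 3's oxygen

This account rests on a few compounds, and the source may have more. Where it says the series, first, only, none or still open, it means among the compounds named here.

Measured compounds in an ADME assay on H1-HeLa cells (Homo sapiens) for cytotoxicity, read by MTT assay, with a stated time of 3 days (a lower number here means that less compound is tolerated, a higher number that more compound is tolerated), are these:
compound 1 `CCOC(=O)c1sc2cc(Oc3ccccc3)ccc2c1C` gives > 100000 nM as a limit
compound 2 `CCOC(=O)c1cc2ccc(OC)cc2s1` gives 70900 nM as a number
compound 3 `CCOC(=O)c1sc2cc(OC)ccc2c1C` gives > 100000 nM as a limit

Compound 3 sits at > 100000 nM in this assay as a limit and not as a number. Compound 1 likewise returns only a limit. Compound 3 therefore stands at the limit of > 100000 nM in this assay, at which 2 of the 3 values shown sit, and has no exact place on the scale.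

The change to compound 4 `CCOC(=O)c1sc2cc(O)ccc2c1C` is hydrogen in place of methyl on an oxygen on an aromatic ring, or methoxy to hydroxy (hydrogen in place of methyl on an oxygen on an aromatic ring). Going by the values given here, two measured steps bear on it. On the same kind of oxygen, methyl in place of phenyl is a step that the two limits leave unreadable from compound 1 to compound 3 and gives no size. Methyl in place of hydrogen on an aromatic carbon is an at least 1.4-fold higher number from compound 2 to compound 3 (0.14 log units; that floor lies within the scatter) and concerns a different place, so it says little about this change.

No measured step sizes the change directly. Among the compounds with values here, compound 2 gives 70900 nM as the only readable number, so a step of no great size is expected in this assay with a somewhat lower number if it can be read at all. Another limit remains quite possible for compound 4. The expected move is an at least 1.4-fold lower number from compound 3 to compound 4 (0.15 log units; that floor lies within the scatter) as an estimate only. For compound 4 the estimated half-maximal cytotoxic concentration is 70000 nM with 25000 nM to 160000 nM as the expected range.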

Compound 4, half-maximal cytotoxic concentration: 82000 nM
Compound 4: middle estimate off by 1.2-fold (0.07 log units), on the low side; the range from low to high includes it.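

In this assay, the hydroxy group on the aromatic ring gives compound 4 a readable number, which neither the methyl nor the phenyl on the same oxygen had given on this core. Hydrogen in place of methyl on this oxygen is an at least 1.2-fold lower number from compound 3 to compound 4 (0.08 log units; that floor lies within the scatter), and hydrogen in place of phenyl is an at least 1.2-fold lower number from compound 1 to compound 4 (0.08 log units; that floor lies within the scatter). Each is only a floor, and the true size of both steps stays unknown because compound 1 and compound 3 rest on the same limit: the limit of > 100000 nM in this assay, at which 2 of the 4 values shown sit.

The compounds shown do not tell how a longer chain on this oxygen, or an amine in place of the oxygen, would read in this assay, so the three groups seen here give only a narrow view of this position. Going by these compounds alone, they also leave open how the hydroxy group would read on the core without the methyl on the aromatic carbon, since the only compound lacking that methyl carries a methoxy group.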